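The source may report more compounds than this note shows. Statements on the series, on what has been measured and on what is new or still open speak of the compounds shown alone.

Measured compounds:
- compound 1 `Cc1ncnc2c1c(-c1cccs1)cn2[C@@H]1O[C@H](CO)[C@@H](O)[C@H]1O` — in a functional assay on CEM-DNR-bulk cells (Homo sapiens), read by MTT assay, with a stated time of 72 h (a lower number here means a stronger inhibitor, a higher number a weaker inhibitor), compound 1 gives > 20000 nM, a limit of the assay, not a number.
- compound 2 `O=c1[nH]cnc2c1c(-c1ccsc1)cn2[C@@H]1O[C@H](CO)[C@@H](O)[C@H]1O` — compound 2 gives > 20000 nM, again a limit.
- compound 3 `CNc1ncnc2c1c(-c1cccs1)cn2[C@@H]1O[C@H](CO)[C@@H](O)[C@H]1O` — compound 3 gives > 20000 nM, also a limit.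

Compound 2 thus stands at the limit, together with every other value shown (the limit of > 20000 nM in this assay, at which 3 of the 3 values shown sit). Among the measured compounds shown here, the one measured step, a step that the two limits leave unreadable from compound 1 to compound 3, runs between two limits and yields no size. Compound 4 `O=c1[nH]cnc2c1c(-c1ccoc1)cn2[C@@H]1O[C@H](CO)[C@@H](O)[C@H]1O` differs from compound 2 by furan-3-yl in place of thiophen-3-yl on an aromatic carbon. No measured step touches this change; nothing shown departs from the limit. The estimate therefore places compound 4 at the limit as well, with an expected step that the limit leaves unreadable from compound 2 to compound 4. The value expected for compound 4 is 40000 nM, within 12000 nM to 150000 nM.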

Compound 4, half-maximal inhibitory concentration: > 20000 nM
Compound 4 ended at the assay's limit; the forecaster's own chance of this, stated with the estimate: 85%; the middle value is on the limit's open side.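

Among the compounds shown here, compound 4 gives > 20000 nM, a limit and not a number, so no step from compound 2 to compound 4 can be read. Left open is whether furan-3-yl and thiophen-3-yl differ at all, and how far any compound lies past the limit: the limit of > 20000 nM in this assay, at which 4 of the 4 values shown sit.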